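The source may hold more compounds than are shown below. What is called first, only, known or untested is meant among the compounds shown, and "the series" means these compounds.

Three compounds of the series share one core with a methoxy group on the aromatic ring and differ only in the group on the amide nitrogen. Compound 1 `COc1ccc(/C(C)=C(/C)C(=O)NC2CC2)cc1` gives in a toxicity assay on the whole organism (strain Icem-CET (SPF Caw)) for cytotoxicity, with Mus musculus as the target (a lower number here means that less compound is needed, a higher number that more compound is needed for the effect), a reading of 300 mg/kg. Compound 2 `C#CCNC(=O)/C(C)=C(\C)c1ccc(OC)cc1` gives in this assay 150 mg/kg. Compound 3 `C=CCNC(=O)/C(C)=C(\C)c1ccc(OC)cc1` gives in this assay 300 mg/kg. Among the compounds with values here, the one step that can be drawn is a 2.0-fold higher number from compound 2 to compound 3 (0.30 log units; within the scatter). Compound 2 thus sits at the low end of three numbers that all lie within the scatter of one another, and no gap between any two of them is beyond the scatter.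

Compound 4 `C#CCNC(=O)/C(C)=C(\C)c1ccc(C)cc1` differs from compound 2 by methyl in place of methoxy on an aromatic carbon. Within the data shown here, none of the measured steps touches this place: every measured compound carries the methoxy, so no step in this assay bears on the exchange. With nothing to point to a change, no step beyond the scatter is expected, and no change at the digits printed from compound 2 to compound 4 (within the scatter) is the expected outcome. Compound 4 is therefore estimated at 150 mg/kg in this assay, with a range from 75 mg/kg to 300 mg/kg.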

Compound 4, dose for half-maximal effect: 150 mg/kg
Estimate against measurement, compound 4: no gap at the digits printed; the measured number falls inside the stated range.
By their numbers in this assay, from the lowest: compounds 2, 4, 1 and 3 (each within the scatter of the next).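

Within the data shown here, the step, no change at the digits printed from compound 2 to compound 4 (within the scatter) in this assay, is the first reading on the aromatic carbon para to a large group, since the earlier compounds all carried methoxy there and differed only on the amide nitrogen. With the amide group of compound 2 held constant, methyl in place of methoxy removes the oxygen, with one heavy atom and one hydrogen-bond acceptor fewer, and the reading stays within the scatter, so this exchange gives no sign that the methoxy matters in this assay. No supporting data are available to explain this outcome.

As far as these compounds go, whether an amine, a carboxylic acid or a longer alkoxy chain at this aromatic carbon would stay within the scatter remains open. Also open, from the compounds shown here alone, is whether the methyl exchange reads the same with the amide groups of compound 1 and compound 3.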